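Working notes: aryl change on the aromatic nitrogen

This account rests on a few compounds, and the source may have more. Where it says the series, first, only, none or still open, it means among the compounds named here.

Compound 1 `Oc1cc(C(F)(F)F)ccc1-c1nc(-c2ccccc2O)n(-c2ccc(Br)cc2)n1` gives 69.4% in a functional assay on PC-12 cells (Rattus norvegicus) for cytotoxicity, read by MTT assay, with stated times of 2 h and 24 h, tested at 1 uM; on this read-out higher numbers stand for a stronger effect at the one concentration tested and lower numbers for a weaker effect. Compound 2 `Oc1cc(C(F)(F)F)ccc1-c1nc(-c2ccccc2O)n(-c2ccc(C(F)(F)F)cc2)n1` gives 70.7% in this assay. On the two numbers shown, compound 2 stands level with compound 1, since the step of a number 1.3 percentage points higher from compound 1 to compound 2 (within the scatter) lies within the scatter and the two compounds cannot be told apart on this read-out.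

Compound 3 `Oc1cc(C(F)(F)F)ccc1-c1nc(-c2ccccc2O)n(-c2ccccc2Cl)n1` differs from compound 2 in one place: 2-chlorophenyl in place of 4-(trifluoromethyl)phenyl on an aromatic nitrogen. Going by the values given here, the only measured step, a number 1.3 percentage points higher from compound 1 to compound 2 (within the scatter), concerns a different substituent on the same aryl group and stayed within the scatter; no measured step exchanges the whole aryl group, so that part of the change is untested. The expectation for compound 3 therefore rests on the closeness of the two measured values: a step of a number 2.7 percentage points lower from compound 2 to compound 3 (within the scatter) is expected, with no direction beyond the scatter, and a widened range for the untested part. Compound 3 is estimated at 68%, between 50% and 82%.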

Compound 3, a percentage reported as activity, at one concentration (the size of the read-out at that concentration, not a potency): 70.1%
Compound 3: the middle estimate sits 2.1 percentage points below what was measured; low and high end bracket the measured number.
By their numbers in this assay, from the lowest: compounds 1, 3 and 2 (each within the scatter of the next).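

Replacing the whole aryl group on the aromatic nitrogen, and not only its substituent, gives no separation in this assay: the exchange for compound 2 is a number 0.6 percentage points lower from compound 2 to compound 3 (within the scatter) and the exchange for compound 1 is a number 0.7 percentage points higher from compound 1 to compound 3 (within the scatter) on the same read-out. The position therefore accepts 2-chlorophenyl, 4-bromophenyl and 4-(trifluoromethyl)phenyl without a difference that can be read, even though 2-chlorophenyl has fewer heavy atoms than 4-(trifluoromethyl)phenyl. No available data bear on why these three aryl groups read alike.

On these data alone, all three groups are substituted phenyl rings, so it stays open whether a phenyl carrying an amine or a carboxylic acid, or a longer alkyl chain in place of the aryl group, would stand apart from them. As far as these compounds go, with a single concentration behind each number, it also stays open whether other concentrations would separate these compounds.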